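Amino for hydroxy on the shared core

The source may hold more compounds than are shown below. What is called first, only, known or untested is meant among the compounds shown, and "the series" means these compounds.

Measured in a functional assay on L1210 cells (Mus musculus) for inhibition; on this read-out lower numbers stand for stronger inhibition and higher numbers for weaker inhibition:
- compound 1 `NCCCC(NC(=O)c1ccc(NCc2ccc3nc(N)nc(O)c3c2)cc1)C(=O)O`: > 5000 nM
- compound 2 `NCCCC(NC(=O)c1ccc(NCc2ccc3nc(N)nc(N)c3n2)cc1)C(=O)O`: 660 nM

In this assay compound 1 stands at > 5000 nM, which is a limit and not a number. Its true position is therefore open, and any step from it can only be estimated loosely.

Compound 3 `NCCCC(NC(=O)c1ccc(NCc2ccc3nc(N)nc(N)c3c2)cc1)C(=O)O` keeps the rest of compound 1 and has amino in place of hydroxy on an aromatic carbon.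

Where compound 1 carries hydroxy, compound 2 carries amino and gives 660 nM. Its core also differs, so this is only a rough guide. On that basis, stronger inhibition is expected in this assay, with an estimated change an at least 12-fold lower number from compound 1 to compound 3 (1.09 log units; beyond the scatter) that goes beyond the scatter.

For compound 3 the estimated value is 400 nM, with an expected range from 100 nM to 1500 nM.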

Compound 3, half-maximal inhibitory concentration: 280 nM
For compound 3 the middle estimate is 1.4-fold (0.15 log units) above the measured one; the range from low to high includes it.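

In this assay, amino in place of hydroxy on an aromatic carbon, next to the ring nitrogen, now has a direct reading on the shared core, and it gives an at least 17-fold lower number from compound 1 to compound 3 (1.25 log units; beyond the scatter). Compound 2 offered only a rough hint, as its core differs as well, whereas here the counts of hydrogen-bond donors and acceptors and the net charge are the same on both sides, so the step does not follow those counts. Compound 1 stands at > 5000 nM, which is a limit of the assay and not a number.

From the compounds shown here alone, the full size of the step stays open: the limit of > 5000 nM in this assay, at which 1 of the 3 values shown sits. Also open is whether methoxy or methylamino at this position would match amino, and whether the amino result holds with a longer chain carrying the terminal amine.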